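Moving one methoxy group: what change to expect

The source may report more compounds than this note shows. Statements on the series, on what has been measured and on what is new or still open speak of the compounds shown alone.

In an ADME assay on HepG2 2.2.15 cells (Homo sapiens) for cytotoxicity, read by MTT assay, with stated times of 48 h and 9 days (on this read-out higher numbers stand for lower toxicity in this test and lower numbers for higher toxicity in this test), compound 1 `COc1ccc2c(=O)c(/C=C/C(=O)Nc3ccccc3)coc2c1` gives 523000 nM and compound 2 `COc1cccc(NC(=O)/C=C/c2coc3cc(OC)ccc3c2=O)c1` gives 1130000 nM so compound 2 holds the higher of the two numbers. Among the measured compounds shown here, compound 3 `COc1ccc(NC(=O)/C=C/c2coc3cc(OC)ccc3c2=O)cc1` has the same atoms as compound 2, joined differently: 4-methoxyphenyl in place of 3-methoxyphenyl on an amide-type nitrogen Only one measured step bears on this change. Putting methoxy in place of hydrogen on an aromatic carbon gave a 2.2-fold higher number from compound 1 to compound 2 (0.33 log units; beyond the scatter) which is modest, though beyond the scatter. That step added a group, whereas here 4-methoxyphenyl simply replaces 3-methoxyphenyl on an amide-type nitrogen, so the data offer no firm direction. The expected result is no change beyond the scatter, with an estimated 1.3-fold lower number from compound 2 to compound 3 (0.10 log units; within the scatter) in this assay as the working figure. The estimate for compound 3 is 900000 nM with an expected range from 400000 nM to 2000000 nM for repeated measurements.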

Compound 3, half-maximal cytotoxic concentration: 718000 nM
The estimate for compound 3 lay 1.3-fold (0.10 log units) above the measured number; low and high end bracket the measured number.
By their numbers in this assay, from the lowest: compounds 1, 3 and 2 (each within the scatter of the next, the first and the last beyond it).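

In this assay, the change from 3-methoxyphenyl to 4-methoxyphenyl on the amide-type nitrogen gives a 1.6-fold lower number from compound 2 to compound 3 (0.20 log units; within the scatter), so these data do not separate the two arrangements. Methoxy in place of hydrogen gives a 1.4-fold higher number from compound 1 to compound 3 (0.14 log units; within the scatter), whereas the earlier step to compound 2 lay just beyond the scatter, so a clear difference from compound 1 is seen with 3-methoxyphenyl but not with 4-methoxyphenyl. Nothing available explains these small differences.

The compounds shown leave open whether another group on the aromatic ring attached to the amide-type nitrogen, such as an amine, a carboxylic acid or a longer chain, would move the number well beyond the scatter. They also leave open what the methoxy group on the shared core contributes, as it is present in all three compounds.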